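This account rests on a few compounds, and the source may have more. Where it says the series, first, only, none or still open, it means among the compounds named here.

Compound 1 `O=C(O)c1cccc([C@H]2C[C@@H]2c2ccc(OCc3c(-c4c(Cl)cccc4Cl)noc3C3CC3)cc2Cl)c1`: 88%
Compound 2 `O=C(O)c1cccc(C2CC2c2ccc(OCc3c(-c4c(Cl)cccc4Cl)noc3C3CC3)cc2Cl)c1`: 87%
Compound 3 `CC(C)n1nc(C(=O)O)cc1C1CC1c1ccc(OCc2c(-c3c(Cl)cccc3Cl)noc2C2CC2)cc1Cl`: 81%

All three values come from an assay on HEK293 cells for agonist activity at Bile acid receptor (Homo sapiens); on this read-out lower numbers stand for smaller maximal responses and higher numbers for larger maximal responses. Compound 3 gives the smallest of the three numbers, yet its gaps to compound 2 and to compound 1 are both within the scatter, so the three compounds cannot be told apart on this read-out.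

Compound 4 `O=C(O)c1cncc(C2CC2c2ccc(OCc3c(-c4c(Cl)cccc4Cl)noc3C3CC3)cc2Cl)c1` differs from compound 3 in one place: 5-carboxypyridin-3-yl in place of 3-carboxy-1-isopropyl-1H-pyrazol-5-yl on a saturated ring carbon. The measured step that bears most on this is the earlier exchange of the acid-bearing aromatic group on the same saturated ring carbon, which gave a number 6 percentage points lower from compound 2 to compound 3 (within the scatter). The other step, a number 1 percentage points lower from compound 1 to compound 2 (within the scatter), concerns only the drawn configuration the fact that one of compounds 1 and 2 is drawn with a defined configuration and the other without, at the place where they differ and says little here. A change of a number 2 percentage points higher from compound 3 to compound 4 (within the scatter) is therefore expected, nothing beyond the scatter. Compound 4 is estimated at 83%, between 70% and 94%.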

Compound 4, largest response reached (reported as efficacy), in percent of the reference or control that the assay uses in the Bile acid receptor assay: 73%
Compound 4: the middle estimate sits 10 percentage points above what was measured; the range from low to high includes it.
By their numbers in the Bile acid receptor assay, from the lowest: compounds 4, 3, 2 and 1 (each within the scatter of the next, the first and the last beyond it).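

Exchanging the acid-bearing aromatic group on this saturated ring carbon can move the maximal response beyond the scatter: 5-carboxypyridin-3-yl in place of 3-carboxyphenyl gives a number 14 percentage points lower from compound 2 to compound 4 (beyond the scatter), and the matching exchange of the whole cyclopropyl group gives a number 15 percentage points lower from compound 1 to compound 4 (beyond the scatter), although the exchange for the pyrazole group gives only a number 8 percentage points lower from compound 3 to compound 4 (within the scatter). In a physicochemical assay for solubility (on this read-out lower numbers stand for lower solubility and higher numbers for higher solubility), compound 3 gives 158000 nM and compound 4 gives 165000 nM, two values within the scatter of each other.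

From the compounds shown here alone, whether an amide in place of the carboxylic acid, or a methyl group on the pyridine ring, would change the response stays open. Nothing given here explains the lower response of compound 4.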